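The source may report more compounds than this note shows. Statements on the series, on what has been measured and on what is new or still open speak of the compounds shown alone.

Notes on the series. Compound 1 `N=C(N)Nc1cccc(C(=O)NNC(=O)NC(CC(=O)O)C(N)=O)c1` gives -2.42 in a physicochemical assay for lipophilicity; on this read-out lower numbers stand for lower lipophilicity and higher numbers for higher lipophilicity; compound 2 `N=C(N)Nc1cccc(C(=O)NNC(=O)NC(CC(=O)O)c2ccc(F)cc2)c1` gives 0.86; compound 3 `N=C(N)Nc1cccc(C(=O)NNC(=O)NC(CC(=O)O)c2cccc3ccccc23)c1` gives 1.7, the highest of the three, with a number 0.84 log units higher from compound 2 to compound 3 (beyond the scatter) and a number 4.12 log units higher from compound 1 to compound 3 (beyond the scatter) behind it. Within the data shown here, every measured step so far, including a number 3.28 log units higher from compound 1 to compound 2 (beyond the scatter), alters the group on the saturated chain carbon only. Compound 4 `O=C(O)CC(NC(=O)NNC(=O)CCCCNc1ccccn1)c1cccc2ccccc12` changes a different place: a group of 11 heavy atoms (9 carbon, 2 nitrogen; one six-membered aromatic ring with 1 hetero atom) in place of a group of 10 heavy atoms (7 carbon, 3 nitrogen; one six-membered aromatic ring of carbon only), on a carbonyl carbon. Among the measured compounds shown here, no measured step touches that carbonyl carbon, so none bears directly on this change, and the expectation rests on the counts alone. A rise beyond the scatter is expected, estimated as a number 1.30 log units higher from compound 3 to compound 4 (beyond the scatter) in this assay. Compound 4 is expected to give 3, within 2 to 4.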

Compound 4, partition coefficient: 2.64
The estimate for compound 4 lay 0.36 log units above the measured number; the range from low to high includes it.
By their numbers in this assay, from the lowest: compound 1; then compound 2; then compound 3; then compound 4.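

With naphthalen-1-yl held fixed, 4-((pyridin-2-yl)amino)butyl in place of the group of 10 heavy atoms on the carbonyl carbon gives a number 0.94 log units higher from compound 3 to compound 4 (beyond the scatter) in this assay. This carbonyl carbon is therefore a second place in the series at which the read-out moves beyond the scatter. Nothing available accounts for the rise.

As far as these compounds go, the exchange alters the ring and the chain together, so the part responsible for the step stays open. Also open, from the compounds shown here alone, is how a plain aminobutyl group or a longer chain ending in the same pyridin-2-ylamino group would read.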